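A few compounds are considered here, and "the series" means these few. Any claim that something is new, unique, unknown or untested is made for them only; others in the source may bear on it.

Of the compounds shown here, three have a measured value so far in a functional assay on NT2 cells (Homo sapiens) for inhibition (a lower number here means a stronger inhibitor, a higher number a weaker inhibitor), and compound 1 `CCC(C(=O)N[C@@H](CC(=O)O)C(=O)CSCc1ccccc1)n1ccnc(NCc2cncs2)c1=O` gives 3.42 nM there. It is the weakest inhibitor of the three, with its gap to each of the other two beyond the scatter. Compound 4 `CCC(C(=O)N[C@@H](CC(=O)O)C(=O)CSCc1ccccc1)n1ccnc(NCc2nc(C)no2)c1=O` still awaits measurement. It differs from compound 1 in a single place 3-methyl-1,2,4-oxadiazol-5-yl in place of 1,3-thiazol-5-yl on a saturated chain carbon bound to a nitrogen on an aromatic ring with 3-methyl-1,2,4-oxadiazol-5-yl in place of 1,3-thiazol-5-yl on a saturated chain carbon bound to a nitrogen on an aromatic ring. Within the data shown here, no measured pair isolates this swap. Compound 3 `CCC(C(=O)N[C@@H](CC(=O)O)C(=O)CNCN1CCCC1)n1ccnc(NCc2nonc2C)c1=O` at 0.84 nM and compound 2 `CCC(C(=O)N[C@@H](CC(=O)O)C(=O)CNCN1CCCCC1)n1cc(C(C)(C)C)nc(NCc2nonc2C)c1=O` at 0.29 nM carry a different ring there, but they also differ from compound 1 elsewhere, so their lower numbers give only a slight lean downward. In this assay a small move toward a lower number is expected, with no step beyond the scatter, and the estimated change is a 1.4-fold lower number from compound 1 to compound 4 (0.14 log units; within the scatter) in size. The value expected for compound 4 is 2.5 nM within an estimated range from 0.8 nM to 8 nM on repeated measurement.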

Compound 4, half-maximal inhibitory concentration: 5.33 nM
For compound 4 the middle estimate is 2.1-fold (0.33 log units) below the measured one; measured number inside the range.
By their numbers in this assay, from the lowest: compound 2; then compound 3; then compounds 1 and 4 (each within the scatter of the next).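

In this assay, among these compounds, this pair is the first to isolate the ring on a saturated chain carbon bound to a nitrogen on an aromatic ring, and it reads a 1.6-fold higher number from compound 1 to compound 4 (0.19 log units; within the scatter). With the rest of compound 1 held fixed, 3-methyl-1,2,4-oxadiazol-5-yl can therefore stand in for 1,3-thiazol-5-yl with no change that can be told apart from the scatter, so this particular swap does not set the potency here. Nothing available bears on why the two rings read alike.

Going by these compounds, it remains open whether a phenyl ring, a pyridine ring or an amine at this place would move the number beyond the scatter. On these data alone, it is also open whether the same swap would read alike with the rest of the molecule different from compound 1.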